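A benzyl swap on compound 2

A few compounds are considered here, and "the series" means these few. Any claim that something is new, unique, unknown or untested is made for them only; others in the source may bear on it.

Of the compounds shown here, three sharing one core have been tested in an ADME assay on L929 cells (Mus musculus) for cytotoxicity; on this read-out lower numbers stand for stronger inhibition and higher numbers for weaker inhibition. Compound 1 (`COC(=O)c1cccc(COc2c(-c3ccc(OCCOCCN=[N+]=[N-])cc3)oc3ccccc3c2=O)c1`) gives 67500 nM. Compound 3 (`COC(=O)c1cccc(COc2c(-c3ccc(OCCOCCOCCn4cc(CCCCOc5ccc(C=O)cc5)nn4)cc3)oc3ccccc3c2=O)c1`) gives 37800 nM. Compound 2 (`COC(=O)c1cccc(COc2c(-c3ccc(OCCCCc4cn(CCOCCO)nn4)cc3)oc3ccccc3c2=O)c1`) stands lowest of the three at 13300 nM, which makes it the strongest inhibitor of this small set, clearly apart from both of the others.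

Compound 4 (`COC(=O)c1cccc(COc2c(-c3ccc(OCCCCc4cn(Cc5ccccc5)nn4)cc3)oc3ccccc3c2=O)c1`) keeps the whole of compound 2 except for one chain end: phenyl in place of (2-hydroxyethoxy)methyl on a saturated chain carbon bound to an aromatic nitrogen. The same difference, cut one bond further out, reads 2-(2-hydroxyethoxy)ethyl to benzyl.

For the measured compounds named here, no two measured compounds differ in only one place, so this change has no direct precedent in the data. With compound 2 already lowest at 13300 nM and compound 3 nearest at 37800 nM, no step beyond the scatter is expected in this assay, only a slight lean towards a higher number. The estimate therefore means a 1.4-fold higher number from compound 2 to compound 4 (0.13 log units; within the scatter), an expected step of modest size. For compound 4 the expected value is 18000 nM, within an estimated range of 6500 nM to 50000 nM.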

Compound 4, half-maximal inhibitory concentration: > 100000 nM
Compound 4: a limit, no number; the forecaster's own chance of this, stated with the estimate: 15%; at least 5.5-fold (0.74 log units) between middle value and limit.
By their numbers in this assay, from the lowest: compound 2; then compounds 3 and 1 (each within the scatter of the next). At a limit, above all of these: compound 4.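

In this assay compound 4 gives > 100000 nM, which is a limit of the assay and not a number. For the compounds shown here, this is the first measured pair in the set that differs in only one place, and it shows that the chain end on a saturated chain carbon bound to an aromatic nitrogen matters in this read-out: phenyl in place of (2-hydroxyethoxy)methyl gives an at least 7.5-fold higher number from compound 2 to compound 4 (0.87 log units; beyond the scatter), a shift towards weaker inhibition. The true size of the step cannot be read, only its lower bound, and compound 4 is the only compound shown that stands at the top of the read-out: the limit of > 100000 nM in this assay, at which 1 of the 4 values shown sits.

The swap brings in an aromatic ring of carbon only while it removes the hydroxyl group and the ether oxygen, so this one pair cannot separate the gain of the ring from the loss of those oxygen atoms. As far as these compounds go, it remains open whether a cyclohexylmethyl group, a 2-methoxyethyl chain, or a chain ending in an amine or a carboxylic acid would read close to compound 2 or close to compound 4.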